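This account rests on a few compounds, and the source may have more. Where it says the series, first, only, none or still open, it means among the compounds named here.

Measured so far in a functional assay on LNCaP cells (Homo sapiens) for antiproliferative activity; on this read-out higher numbers stand for weaker inhibition and lower numbers for stronger inhibition:
- compound 1 `CC(=O)OCC[C@@H]1C[C@@H](c2ccc(F)c(F)c2)[C@H](NC(=O)c2cc(-c3c(Cl)cnn3C)c(Cl)o2)CN1` — "not determined" (no result reported)
- compound 2 `Cn1ncc(Cl)c1-c1cc(C(=O)N[C@@H]2CN[C@H](CC(=O)NCC(O)CO)C[C@H]2c2ccc(Cl)c(Cl)c2)oc1Cl` — 660 nM

Among the measured compounds shown here, compound 2 carries the only number in this assay; compound 1 stands without one, so no step between measured compounds can be read. Compound 3 `Cn1ncc(Cl)c1-c1cc(C(=O)N[C@@H]2CN[C@H](CCN3CCCCC3)C[C@H]2c2ccc(Cl)c(Cl)c2)oc1Cl` is not yet measured. It differs from compound 2 in one place: (piperidin-1-yl)methyl in place of (2,3-dihydroxypropyl)carbamoyl on a saturated chain carbon bound to a saturated ring carbon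

For the measured compounds named here, with no measured step to lean on, the expected change is a modest one toward stronger inhibition, not much beyond the scatter. Compound 3 is estimated at 400 nM in this assay, within 120 nM to 1500 nM, meaning a step of a 1.7-fold lower number from compound 2 to compound 3 (0.22 log units; within the scatter).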

Compound 3, half-maximal inhibitory concentration: 1780 nM
Compound 3: the middle estimate sits 4.5-fold (0.65 log units) below what was measured; measured number above the stated range.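

In this assay, this position on a saturated chain carbon bound to a saturated ring carbon responds to the group it carries: (piperidin-1-yl)methyl in place of (2,3-dihydroxypropyl)carbamoyl gives a 2.7-fold higher number from compound 2 to compound 3 (0.43 log units; beyond the scatter) while inhibition remains measurable. The whole group changes in this one step, so the contributions of the carbonyl, the hydroxyl groups and the piperidine ring cannot be separated. No measurement on hand accounts for the step.

Open, on these data alone, is where a carboxylic acid or a primary amine at this position would fall relative to compound 2 and compound 3.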